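This account rests on a few compounds, and the source may have more. Where it says the series, first, only, none or still open, it means among the compounds named here.

Measured compounds in a functional assay on DU-145 cells (Homo sapiens) for antiproliferative activity, read by MTT assay, with a stated time of 48 h; a lower number here means a stronger inhibitor, a higher number a weaker inhibitor:
Compound 1 `C/C(=C\CC/C(C)=C/CC[C@@H]1[C@@]2(C)CCC(=O)C(C)(C)[C@H]2CC[C@@]1(C)O)CC/C=C(\C)C(=O)OCc1cn(-c2ccccc2Cl)nn1` gives > 150000 nM, which is a limit of the assay.
Compound 2 `C/C(=C\CC/C(C)=C/CC[C@@H]1[C@@]2(C)CCC(=O)C(C)(C)[C@H]2CC[C@@]1(C)O)CC/C=C(\C)C(=O)OCc1cn(-c2cccc(Cl)c2)nn1` gives 103000 nM.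
Compound 3 `C/C(=C\CC/C(C)=C/CC[C@@H]1[C@@]2(C)CCC(=O)C(C)(C)[C@H]2CC[C@@]1(C)O)CC/C=C(\C)C(=O)OCc1cn(-c2ccccc2[N+](=O)[O-])nn1` gives > 150000 nM, again a limit rather than a number.

Compound 3 therefore stands at the limit (the limit of > 150000 nM in this assay, at which 2 of the 3 values shown sit), where a second compound also sits; only a limit is known for it. Compound 4 `C/C(=C\CC/C(C)=C/CC[C@@H]1[C@@]2(C)CCC(=O)C(C)(C)[C@H]2CC[C@@]1(C)O)CC/C=C(\C)C(=O)OCc1cn(-c2ccc(C)cc2)nn1` differs from it by 4-methylphenyl in place of 2-nitrophenyl on an aromatic nitrogen. The steps reaching compound 3 were a step that the two limits leave unreadable from compound 1 to compound 3 and an at least 1.4-fold higher number from compound 2 to compound 3 (0.16 log units; that floor lies within the scatter); neither involves a methylphenyl, so they set no direction for this change. All values here are weak, and the expectation is that compound 4 stays near the limit, with a number no higher from compound 3 to compound 4 (the limit leaves the size open) expected to fall within the scatter. Compound 4 is estimated at 150000 nM, in the range 60000 nM to 300000 nM.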

Compound 4, half-maximal inhibitory concentration: > 150000 nM
Compound 4 was reported as a limit; the forecaster's own chance of this, stated with the estimate: 60%; the middle value lies on the limit itself.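

In this assay compound 4 gives > 150000 nM as a limit of the assay, not a number. So 4-methylphenyl, a ring carrying neither chloro nor nitro, also leaves the compound at this limit: the limit of > 150000 nM in this assay, at which 3 of the 4 values shown sit. Among these compounds, the one readable step is an at least 1.4-fold higher number from compound 2 to compound 4 (0.16 log units; that floor lies within the scatter) and the steps from compound 1 and from compound 3 cannot be read.

As far as these compounds go, what stays open is whether an amine or a carboxylic acid on this phenyl ring, or a longer chain in its place, would give a value clear of the limit.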